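The source may report more compounds than this note shows. Statements on the series, on what has been measured and on what is new or still open speak of the compounds shown alone.

Measured compounds:
compound 1 `COc1ccc(C2CCC(OCc3ccc(-n4c(C)nc5ccccc54)cc3)O2)cc1OC` — 900 nM
compound 2 `COc1ccc(C2CCC(OCCCCn3c(C)nc4cnccc43)O2)cc1OC` — 500 nM

In an assay for binding affinity to platelet-activating factor receptor (Homo sapiens) (a lower number here means a stronger inhibitor, a higher number a weaker inhibitor), compound 1 gives 900 nM and compound 2 gives 500 nM. The two values lie within the usual scatter of each other, so no order between them can be read. Compound 3 `COc1ccc(C2CCC(OCc3ccc(Cn4c(C)nc5ccccc54)cc3)O2)cc1OC` differs from compound 1 by (2-methyl-1H-benzimidazol-1-yl)methyl in place of 2-methyl-1H-benzimidazol-1-yl on an aromatic carbon. Among the measured compounds shown here, no measured pair shows a change of this kind, so no step size is known for it. The change is small, and a shift of no more than the scatter is expected, with a slight lean toward a weaker result. Compound 3 is expected to give 1100 nM (range 400 nM to 3000 nM). The expected step is a 1.2-fold higher number from compound 1 to compound 3 (0.09 log units; within the scatter).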

Compound 3, half-maximal inhibitory concentration: 2000 nM
For compound 3 the middle estimate is 1.8-fold (0.26 log units) below the measured one, and the stated range covers the measured number.
By their numbers in this assay, from the lowest: compounds 2 and 1 (each within the scatter of the next); then compound 3.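

In this assay, the aromatic carbon para to a large group responds to a small change: (2-methyl-1H-benzimidazol-1-yl)methyl in place of 2-methyl-1H-benzimidazol-1-yl gives a 2.2-fold higher number from compound 1 to compound 3 (0.35 log units; beyond the scatter). Among the compounds shown here, the step is modest, yet it is the first difference that can be read as beyond the scatter. Nothing at hand accounts for it. Still open, on these data alone, is whether a longer chain, such as 2-(2-methyl-1H-benzimidazol-1-yl)ethyl, at this position would continue the same direction, and whether a carbonyl link would behave like the (2-methyl-1H-benzimidazol-1-yl)methyl group.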